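Compound 1 to compound 4: stability behind a limit

A few compounds are considered here, and "the series" means these few. Any claim that something is new, unique, unknown or untested is made for them only; others in the source may bear on it.

Compound 1 `CNC(=O)Nc1ccc(-c2nc(N3CC4CCC(C3)O4)c3cnn(C)c3n2)cc1` gives > 0.5 h in an in vitro ADME assay on microsomes (Mus musculus) for metabolic stability (on this read-out lower numbers stand for a shorter-lived compound and higher numbers for a longer-lived compound), which is a limit and not a number. Compound 2 `O=C(Nc1ccccc1)Nc1ccc(-c2nc(N3CC4CCC(C3)O4)c3cnn(C4CCC5(CC4)OCCO5)c3n2)cc1` gives > 0.5 h, also a limit. Compound 3 `O=C(Nc1ccc(-c2nc(N3CC4CCC(C3)O4)c3cnn(C4CCC5(CC4)OCCO5)c3n2)cc1)Nc1cccnc1` gives > 0.5 h, again a limit. The series therefore offers only (the limit of > 0.5 h in this assay, at which 3 of the 3 values shown sit). Compound 4 `CNC(=O)Nc1ccc(-c2nc(N3CC4CCC(C3)O4)c3cnn([C@H]4CC[C@@H](O)CC4)c3n2)cc1` carries 4-hydroxycyclohexyl in place of methyl on an aromatic nitrogen. For the measured compounds named here, the one measured step, a step that the two limits leave unreadable from compound 2 to compound 3, concerns a different change and gives no size to carry over. Going by these compounds, no step beyond the scatter is therefore expected in this assay, and the direction stays open. The expected step is a number no higher from compound 1 to compound 4 (the limit leaves the size open). For compound 4 the estimated half-life is 0.5 h, with an expected range of 0.25 h to 1 h.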

Compound 4, half-life: > 0.5 h
Compound 4: only a limit was reported (the forecaster's own chance of this, stated with the estimate: 65%); the middle value lies on the limit itself.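

The step from compound 1 to compound 4 cannot be read, as both values are limits. Still open are the actual half-lives of compound 1, compound 2, compound 3 and compound 4 in this assay, and how they rank: the limit of > 0.5 h in this assay, at which 4 of the 4 values shown sit.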